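The source may report more compounds than this note shows. Statements on the series, on what has been measured and on what is new or still open speak of the compounds shown alone.

In a functional assay on HCT-116 cells (Homo sapiens) for inhibition, read by MTT assay, with a stated time of 72 h (a higher number here means a weaker inhibitor, a lower number a stronger inhibitor), compound 1 `CCOC(=O)c1oc2ccc(NS(=O)(=O)c3ccc(Cl)cc3)cc2c1C` reaches only the limit of the assay, > 40000 nM, which is a limit and not a number. Going by the values given here, compound 2 `CCOC(=O)c1oc2ccc(N(Cc3ccccc3)S(=O)(=O)c3ccc(Cl)cc3)cc2c1C` gives 23200 nM in this assay, the only measured number here. Among the compounds with values here, the one measured step, an at least 1.7-fold lower number from compound 1 to compound 2 (0.23 log units; that floor lies within the scatter), rests on that limit (the limit of > 40000 nM in this assay, at which 1 of the 2 values shown sits). Compound 3 `CCOC(=O)c1oc2ccc(N(Cc3ccc(Cl)cc3)S(=O)(=O)c3ccc(Cl)cc3)cc2c1C` differs from compound 2 by chloro in place of hydrogen on an aromatic carbon. Within the data shown here, no measured step touches that carbon, so compound 3 is expected to move by a 1.5-fold lower number from compound 2 to compound 3 (0.19 log units; within the scatter), a step not beyond the scatter. Compound 3 is therefore estimated at 15000 nM, between 6000 nM and 40000 nM.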

Compound 3, half-maximal inhibitory concentration: 9640 nM
Compound 3: middle estimate off by 1.6-fold (0.19 log units), on the high side; the range from low to high includes it.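

In this assay, going by these compounds alone, the change from benzyl to 4-chlorobenzyl gives the first step on this ring, and it lies beyond the scatter (a 2.4-fold lower number from compound 2 to compound 3 (0.38 log units; beyond the scatter)). The whole 4-chlorobenzyl group in place of hydrogen on the sulfonamide nitrogen also clears the scatter (an at least 4.1-fold lower number from compound 1 to compound 3 (0.61 log units; beyond the scatter)), whereas the floor of the benzyl step alone did not. That larger step is only a floor, since it rests on a limit and not a number: the limit of > 40000 nM in this assay, at which 1 of the 3 values shown sits.

The compounds shown leave open whether a fluorine, a methyl group or a methoxy group in place of this chloro would move the number the same way.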